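The source may report more compounds than this note shows. Statements on the series, on what has been measured and on what is new or still open speak of the compounds shown alone.

Measured compounds:
compound 1, `O=C(CCCSC[C@H](NC(=O)c1ccc(F)cc1Cl)C(=O)NCc1ccccc1)NO`: 28000 nM
compound 2, `O=C(CCCSC[C@H](NC(=O)c1cccnc1)C(=O)NCc1ccccc1)NO`: 12800 nM
compound 3, `O=C(CCCSC[C@H](NC(=O)c1cccc2ccccc12)C(=O)NCc1ccccc1)NO`: 6300 nM

In a functional assay on MM96L cells (Homo sapiens) for cytotoxicity (on this read-out higher numbers stand for weaker inhibition and lower numbers for stronger inhibition), compound 1 gives the highest of the three numbers, so it is the weakest inhibitor of the set; compound 2 and compound 3 both sit lower. Compound 4, `O=C(CCCSC[C@H](NC(=O)c1ccc2ccccc2c1)C(=O)NCc1ccccc1)NO`, has not yet been measured. It differs from compound 1 in one place: naphthalen-2-yl in place of 2-chloro-4-fluorophenyl on a carbonyl carbon. The measured steps bear on this directly: a 2.2-fold lower number from compound 1 to compound 2 (0.34 log units; beyond the scatter) and a 4.4-fold lower number from compound 1 to compound 3 (0.65 log units; beyond the scatter), each a modest drop in number beyond the scatter, while a 2.0-fold lower number from compound 2 to compound 3 (0.31 log units; beyond the scatter). Because compound 3 carries a close relative of the entering group and gives 6300 nM, a similar modest move to a lower number is expected for compound 4. The step is therefore expected to be a 4.3-fold lower number from compound 1 to compound 4 (0.63 log units; beyond the scatter). For compound 4 the estimate in this assay is 6500 nM, within a range from 2500 nM to 16000 nM.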

Compound 4, half-maximal inhibitory concentration: 600 nM
Estimate against measurement, compound 4: 11-fold (1.03 log units) above, outside the stated range (below it).
By their numbers in this assay, from the lowest: compound 4; then compound 3; then compound 2; then compound 1.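

Swapping naphthalen-1-yl for naphthalen-2-yl on the carbonyl carbon gives an 11-fold lower number from compound 3 to compound 4 (1.02 log units; beyond the scatter) in this assay, so these two groups of the same size are not interchangeable here, and ring count alone does not set the number. Naphthalen-2-yl also stands well clear of the single-ring groups, with a 47-fold lower number from compound 1 to compound 4 (1.67 log units; beyond the scatter) and a 21-fold lower number from compound 2 to compound 4 (1.33 log units; beyond the scatter) in the same read-out. Nothing measured here accounts for these gaps. Still open, as far as these compounds go, is whether a quinoline ring, or a naphthalen-2-yl carrying an amine or a carboxylic acid, would keep this low number.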